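The compounds below may be only part of what the source reports. "The series", "measured", "known", "first", "only" and "open" are said of these compounds alone.

Compound 3 `Cc1cn([C@@H]2O[C@H](CO[Si](C)(C)C(C)(C)C)[C@@]3(OS(=O)(=O)C=C3NC(N)=O)[C@H]2O[Si](C)(C)C(C)(C)C)c(=O)n(C)c1=O` carries a carbamoyl on the amine nitrogen of the shared core. In a functional assay on CCRF-CEM cells (Homo sapiens) (on this read-out higher numbers stand for lower toxicity in this test and lower numbers for higher toxicity in this test), compound 3 gives 4360 nM, the highest of the two numbers in hand. Compound 1 `CCNC(=O)NC1=CS(=O)(=O)O[C@@]12[C@@H](CO[Si](C)(C)C(C)(C)C)O[C@@H](n1cc(C)c(=O)n(C)c1=O)[C@@H]2O[Si](C)(C)C(C)(C)C`, with ethylcarbamoyl in that place, gives 4260 nM in this assay, and the step of a 1.0-fold higher number from compound 1 to compound 3 (0.01 log units; within the scatter) stays within the scatter. Compound 2 `Cc1cn([C@@H]2O[C@H](CO[Si](C)(C)C(C)(C)C)[C@@]3(OS(=O)(=O)C=C3NCCC(=O)OCc3ccccc3)[C@H]2O[Si](C)(C)C(C)(C)C)c(=O)n(C)c1=O`, with 2-(benzyloxycarbonyl)ethyl on the amine nitrogen, reaches only a limit of this assay, > 250000 nM. The measured steps of an at least 58-fold higher number from compound 1 to compound 2 (1.76 log units; beyond the scatter) and an at least 57-fold lower number from compound 2 to compound 3 (1.75 log units; beyond the scatter) both exchange a carbamoyl-type group for 2-(benzyloxycarbonyl)ethyl or back, and both are large. Compound 4 `COC(=O)CNC1=CS(=O)(=O)O[C@@]12[C@@H](CO[Si](C)(C)C(C)(C)C)O[C@@H](n1cc(C)c(=O)n(C)c1=O)[C@@H]2O[Si](C)(C)C(C)(C)C` makes a change of the same kind, ((methoxycarbonyl)methyl in place of carbamoyl on an amine nitrogen). Those two large steps bear directly on it, so a step toward a higher number is expected, though the group entering is (methoxycarbonyl)methyl rather than 2-(benzyloxycarbonyl)ethyl and need not reach (the limit of > 250000 nM in this assay, at which 1 of the 3 values shown sits). For compound 4 the expected step is an 11-fold higher number from compound 3 to compound 4 (1.06 log units; beyond the scatter). For compound 4 the estimate is 50000 nM, within 8000 nM to 250000 nM.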

Compound 4, half-maximal cytotoxic concentration: 96000 nM
Beside the measured number, compound 4's estimate is 1.9-fold (0.28 log units) below it; the range from low to high includes it.
By their numbers in this assay, from the lowest: compounds 1 and 3 (each within the scatter of the next); then compound 4. At a limit, above all of these: compound 2.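

In this assay, the steps of a 22-fold higher number from compound 3 to compound 4 (1.34 log units; beyond the scatter) and a 23-fold higher number from compound 1 to compound 4 (1.35 log units; beyond the scatter) are both large, so replacing a carbamoyl-type group on the amine nitrogen with an ester-bearing chain now gives a rise that ends in a measured number. The step of an at least 2.6-fold lower number from compound 2 to compound 4 (0.41 log units; beyond the scatter) shows that the two ester-bearing chains are not equivalent, although both lie well above the carbamoyl-type compounds. The value of compound 2 remains a limit and not a number: the limit of > 250000 nM in this assay, at which 1 of the 4 values shown sits.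

On these data alone, whether the rise follows from the ester or only from the loss of the carbamoyl-type group stays open, and a carboxylic acid or a plain ethyl on the same amine nitrogen would separate the two. Chain length and the benzyl ester also vary together between compound 2 and compound 4, leaving open what a longer chain ending in a methyl ester would give.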